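A Repeated Trifluoromethyl Step on Two Related Cores

This account rests on a few compounds, and the source may have more. Where it says the series, first, only, none or still open, it means among the compounds named here.

Compound 2 `COc1cc(NC(C)CCCNC(=O)Nc2cccc(C(F)(F)F)c2)c2ncccc2c1` and compound 1 `COc1cc(NC(C)CCCNC(=O)Nc2cc(C(F)(F)F)cc(C(F)(F)F)c2)c2ncccc2c1` share one core and differ in a single place: trifluoromethyl in place of hydrogen on an aromatic carbon. In a functional assay on NCI-H460 cells (Homo sapiens) for inhibition, read by MTT assay, with a stated time of 72 h (on this read-out higher numbers stand for weaker inhibition and lower numbers for stronger inhibition), compound 2 gives 21000 nM, and compound 1 gives 8300 nM; the step between them is a 2.5-fold lower number from compound 2 to compound 1 (0.40 log units; beyond the scatter). Compound 3 `COc1cc(NC(C)CCCNC(=O)NNC(=O)Nc2cccc(C(F)(F)F)c2)c2ncccc2c1` carries the same aryl end as compound 2 on another core; the difference between the two cores is not broken down here. In this assay compound 3 gives 20000 nM, and against compound 2 this lies within the scatter. Compound 4 `COc1cc(NC(C)CCCNC(=O)NNC(=O)Nc2cc(C(F)(F)F)cc(C(F)(F)F)c2)c2ncccc2c1` stands to compound 3 as compound 1 stands to compound 2: trifluoromethyl in place of hydrogen on an aromatic carbon. The place of the entering group is described in the same words for both changes, so this is the same change carried onto the second core. For compound 4 the step in this assay is expected to be a 2.4-fold lower number from compound 3 to compound 4 (0.37 log units; beyond the scatter), because the one earlier case a 2.5-fold lower number from compound 2 to compound 1 (0.40 log units; beyond the scatter) lies beyond the scatter, though a single precedent is a thin basis. Compound 4 is therefore estimated at 8500 nM, within a range from 4000 nM to 18000 nM.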

Compound 4, half-maximal inhibitory concentration: 18000 nM
Compound 4: the middle estimate sits 2.1-fold (0.33 log units) below what was measured; the measured number falls inside the stated range.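

In this assay, going by these compounds alone, the entry of the second trifluoromethyl on the core of compound 3 comes to a 1.1-fold lower number from compound 3 to compound 4 (0.05 log units; within the scatter), so on this core the change gives no step that stands out from the scatter. Set beside the step on the first core, this one cannot be told apart from it: the same change on two cores in this assay, a 2.5-fold lower number (0.40 log units; beyond the scatter) from compound 2 to compound 1 and a 1.1-fold lower number (0.05 log units; within the scatter) from compound 3 to compound 4, 2.3-fold (0.36 log units) apart, within the scatter of two such steps. Within the data shown here, the data therefore do not show that the change behaves differently on the two cores, but they do not show that it carries over either, as each core offers only one pair, with one step beyond the scatter and the other within it.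

The compounds shown leave open whether a chlorine atom, a nitrile or an amine at the same place on the aryl end would give matching steps on the two cores. They also leave open whether the two steps would stay alike with a longer chain in the linker.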